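The compounds below may be only part of what the source reports. "The series", "measured", "known", "first", "only" and "open" are said of these compounds alone.

Of the compounds shown here, three on a shared core have been tested so far. Compound 1 `Cc1cc(-c2c(F)cc3c(=O)c(Cc4ccc(Cl)cc4)cn(C4CC4)c3c2F)cc(C)n1` gives 20000 nM in a functional assay on P388 cells (Mus musculus) for cytotoxicity; on this read-out lower numbers stand for stronger inhibition and higher numbers for weaker inhibition; compound 2 `Cc1cc(-c2c(F)cc3c(=O)c(Cc4ccccc4)cn(C4CC4)c3c2F)cc(C)n1` gives 7300 nM; compound 3 `Cc1cc(-c2c(F)cc3c(=O)c(C(=O)O)cn(C4CC4)c3c2F)cc(C)n1` gives 29000 nM. Compound 3 sits at the high end of these numbers, though its gap to compound 1 stays within the scatter, as the step of a 1.5-fold higher number from compound 1 to compound 3 (0.16 log units; within the scatter) shows, while the step of a 4.0-fold higher number from compound 2 to compound 3 (0.60 log units; beyond the scatter) is beyond it. Compound 4 `Cc1cc(-c2c(F)cc3c(=O)c(Cc4ccc[nH]4)cn(C4CC4)c3c2F)cc(C)n1` arises from compound 3 by (1H-pyrrol-2-yl)methyl in place of carboxy on an aromatic carbon.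

The two steps that end at compound 3 bear on this change, since each replaces a ring joined through one carbon with carboxy: a 4.0-fold higher number from compound 2 to compound 3 (0.60 log units; beyond the scatter) and a 1.5-fold higher number from compound 1 to compound 3 (0.16 log units; within the scatter). Read backwards, putting such a group back in place of carboxy gave a modestly lower number in one case and a change within the scatter in the other. The entering group is again an aromatic ring joined through one carbon, so a modest drop is expected, estimated as a 2.6-fold lower number from compound 3 to compound 4 (0.42 log units; beyond the scatter). Compound 4 is thus expected to give about 11000 nM, within a range from 4500 nM to 27000 nM.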

Compound 4, half-maximal inhibitory concentration: 930 nM
Compound 4: the middle estimate sits 12-fold (1.07 log units) above what was measured; measured number outside the range, below it.
By their numbers in this assay, from the lowest: compound 4; then compound 2; then compounds 1 and 3 (each within the scatter of the next).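

The position on the shared core that carried carboxy, benzyl or 4-chlorobenzyl can support a far lower number than those three suggested, since (1H-pyrrol-2-yl)methyl gives a 31-fold lower number from compound 3 to compound 4 (1.49 log units; beyond the scatter). A ring joined through one carbon is therefore not enough to set the outcome. The identity of the ring also matters: with the link unchanged, 1H-pyrrol-2-yl in place of phenyl gives a 7.8-fold lower number from compound 2 to compound 4 (0.89 log units; beyond the scatter), and in place of 4-chlorophenyl it gives a 22-fold lower number from compound 1 to compound 4 (1.33 log units; beyond the scatter). No measurement here accounts for the advantage of this ring.

A (furan-2-yl)methyl or (thiophen-2-yl)methyl group would show whether the ring nitrogen carrying its hydrogen is what counts. A longer chain between the pyrrole ring and the core would show whether the one-carbon link is needed.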